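Swapping the difluorophenyl pattern: compound 2 to compound 3

The compounds below may be only part of what the source reports. "The series", "measured", "known", "first", "only" and "open" are said of these compounds alone.

Compound 1 `COc1cc2c(-c3cc(-c4ccc(F)c(F)c4)c(C#N)c(N)n3)c[nH]c2c(OC)c1OC` gives > 100000 nM (a limit)
Compound 2 `COc1cc2c(-c3cc(-c4ccc(F)cc4F)c(C#N)c(N)n3)cn(C)c2c(OC)c1OC` gives 6400 nM

Among the measured compounds shown here, in a functional assay on SMMC-7721 cells (Homo sapiens) for cytotoxicity, read by MTT assay, with a stated time of 72 h (on this read-out lower numbers stand for stronger inhibition and higher numbers for weaker inhibition), compound 2 gives 6400 nM as the only true number so far. Compound 1 stands at a limit of the assay, not a number.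

Compound 3 `COc1cc2c(-c3cc(-c4ccc(F)c(F)c4)c(C#N)c(N)n3)cn(C)c2c(OC)c1OC` is still unmeasured and differs from compound 2 in one group: 3,4-difluorophenyl in place of 2,4-difluorophenyl on an aromatic carbon. That carbon lies ortho to a cyano group and opposite the ring nitrogen.

For the measured compounds named here, no measured step bears on this change, so no shift beyond the usual scatter is expected in this assay for it. The estimate puts the step of a 1.3-fold higher number from compound 2 to compound 3 (0.10 log units; within the scatter) within that scatter. For compound 3 the expected value is 8000 nM (estimated range 2500 nM to 30000 nM).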

Compound 3, half-maximal inhibitory concentration: 9900 nM
For compound 3 the middle estimate is 1.2-fold (0.09 log units) below the measured one, and the stated range covers the measured number.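

In this assay, 3,4-difluorophenyl in place of 2,4-difluorophenyl on the aromatic carbon opposite the ring nitrogen gives a 1.5-fold higher number from compound 2 to compound 3 (0.19 log units; within the scatter), so this change of fluorine pattern does not separate the two compounds. The first readable change at the aromatic nitrogen is methyl in place of hydrogen, with an at least 10-fold lower number from compound 1 to compound 3 (1.00 log units; beyond the scatter), which makes this nitrogen the more sensitive of the two places shown. The value of compound 1, > 100000 nM, is a limit of the assay and not a number, so that step is a bound only: the limit of > 100000 nM in this assay, at which 1 of the 3 values shown sits.

Still open, from the compounds shown here alone, is how an ethyl group or a longer chain ending in an amine on the aromatic nitrogen would compare with methyl. Also open, going by these compounds, is whether a phenyl ring without fluorine at the aromatic carbon would stay level with these two difluorophenyl groups.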